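The compounds below may be only part of what the source reports. "The series", "measured", "known", "first", "only" and "open" are said of these compounds alone.

Series notes. In an assay on HEK293 cells for positive allosteric modulation of metabotropic glutamate receptor 5 (Homo sapiens), read by FLIPR (on this read-out higher numbers stand for an effect only at larger amounts of compound and lower numbers for an effect already at smaller amounts), compound 1 `CC1CCC(C(=O)N2CC(c3nc(-c4cccc(Cl)c4)no3)C2)CC1` gives 1500 nM. Compound 2 `O=C(c1ccccc1F)N1CC(c2nc(-c3cccc(Cl)c3)no2)C1` reaches only a limit of this assay, > 10000 nM; see (the limit of > 10000 nM in this assay, at which 1 of the 3 values shown sits). Compound 3 `O=C(C1CCC2(CCC2)CC1)N1CC(c2nc(-c3cccc(Cl)c3)no2)C1` gives 1100 nM, the lowest of the two numbers shown, with compound 1 nearest, and the step of a 1.4-fold lower number from compound 1 to compound 3 (0.13 log units; within the scatter) lies within the scatter. The steps of an at least 6.6-fold higher number from compound 1 to compound 2 (0.82 log units; beyond the scatter) and an at least 9.0-fold lower number from compound 2 to compound 3 (0.95 log units; beyond the scatter) put the saturated carbocycles on the carbonyl carbon well ahead of the aromatic ring. Compound 4 `CC1CN(C(=O)N2CC(c3nc(-c4cccc(Cl)c4)no3)C2)CC(C)O1` is compound 3 with a group of 8 heavy atoms (6 carbon, 1 nitrogen, 1 oxygen; one six-membered non-aromatic ring with 2 hetero atoms) in place of a group of 9 heavy atoms (9 carbon; one four-membered non-aromatic ring of carbon only, one six-membered non-aromatic ring of carbon only), on a carbonyl carbon. Among the compounds with values here, no measured step exchanges a carbocycle for a ring with hetero atoms, so the only guide is the loss seen on leaving the carbocycles of compound 1 and compound 3. The number for compound 4 is therefore expected to rise modestly, a 3.6-fold higher number from compound 3 to compound 4 (0.56 log units; beyond the scatter). The estimate for compound 4 is 4000 nM, range 1500 nM to 12000 nM.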

Compound 4, half-maximal effective concentration: > 10000 nM
Compound 4: no number, only a limit; the forecaster's own chance of this, stated with the estimate: 30%; at least 2.5-fold (0.39 log units) between middle value and limit.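

On the carbonyl carbon whose other neighbour is the ring amide nitrogen, 2,6-dimethylmorpholin-4-yl does not hold the level of the saturated carbocycles, with an at least 9.0-fold higher number from compound 3 to compound 4 (0.95 log units; beyond the scatter) and an at least 6.6-fold higher number from compound 1 to compound 4 (0.82 log units; beyond the scatter) in this assay. Loss at this place therefore comes with a saturated ring bearing hetero atoms as well as with the aromatic ring of compound 2. Compound 4 gives only a limit, as does compound 2, so the step between them cannot be read: the limit of > 10000 nM in this assay, at which 2 of the 4 values shown sit. From the compounds shown here alone, whether a piperidine, without the ring oxygen, or a cyclohexyl carrying a hydroxyl group keeps the effect remains open.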